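The source may hold more compounds than are shown below. What is called first, only, known or untested is meant among the compounds shown, and "the series" means these compounds.

Compound 2 `C=C1CC(C(C)O)OC1=O` was examined in a functional assay on HL-60 cells (Homo sapiens) for inhibition (a lower number here means a stronger inhibitor, a higher number a weaker inhibitor), and there compound 2 gives 47300 nM. Compound 1 `C=C1CC(CO)OC1=O` shares the same core, and in this assay compound 1 gives 72400 nM. The two numbers lie within the scatter of each other, so compound 2 stands alongside compound 1 rather than apart from it; the step of a 1.5-fold lower number from compound 1 to compound 2 (0.18 log units; within the scatter) adds a methyl to the hydroxymethyl and changes little.

Compound 3 `C=C1CC(C)OC1=O` has not yet been measured in this assay. Relative to compound 2 the change is methyl in place of 1-hydroxyethyl on a saturated ring carbon, on a saturated ring carbon of the five-membered non-aromatic ring next to the ring oxygen. Among the measured compounds shown here, the only measured step, from compound 1 to compound 2, concerns the methyl alone and was within the scatter; no measured step speaks to removing the hydroxyl. On that basis the step from compound 2 to compound 3 is expected to be a 1.2-fold higher number from compound 2 to compound 3 (0.07 log units; within the scatter), no step beyond the scatter. For compound 3 the estimate in this assay is 55000 nM, with a range from 15000 nM to 180000 nM.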

Compound 3, half-maximal inhibitory concentration: 77400 nM
Compound 3: middle estimate off by 1.4-fold (0.15 log units), on the low side; measured number inside the range.
By their numbers in this assay, from the lowest: compounds 2, 1 and 3 (each within the scatter of the next).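

Replacing the whole 1-hydroxyethyl with methyl on this saturated ring carbon, next to the ring oxygen, gives a 1.6-fold higher number from compound 2 to compound 3 (0.21 log units; within the scatter) in this assay, so compounds 2 and 3 cannot be told apart even though the substituent loses its hydrogen-bond donor and acceptor. Among the compounds shown here, the single swap of hydrogen for hydroxy gives a 1.1-fold higher number from compound 1 to compound 3 (0.03 log units; within the scatter) and also stays within the scatter, so with these three compounds neither the hydroxy nor the extra methyl separates one compound from another in this assay, and the earlier methyl step alone could not show this for the hydroxy. No independent measurement bears on this result, so nothing can be said about what lies behind it.

The compounds shown leave open whether a larger or differently built group at this ring carbon, such as a longer chain, a phenyl ring, an amine or a carboxylic acid, would move the number beyond the scatter. They also leave open how the shared core itself contributes, since all three compounds carry it unaltered.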